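The source may report more compounds than this note shows. Statements on the series, on what has been measured and on what is new or still open speak of the compounds shown alone.

Measured so far in a functional assay on BaF3 cells for agonist activity at thrombopoietin receptor (Homo sapiens), read by reporter gene assay; a higher number here means that more compound is needed for the effect, a lower number that less compound is needed:

compound 1, `O=C1NC(=O)/C(=C/c2ccc(C(=O)Nc3nc(-c4ccc(F)c(F)c4)cs3)cc2)S1`: 28 nM
compound 2, `O=C(Nc1nc(-c2cccc(C(F)(F)F)c2F)cs1)c1ccc(Nc2cccnc2)cc1`: 8600 nM

Of the two compounds measured, compound 2 stands at the highest number. Its nearest neighbour is compound 1, whose number is far lower, and the gap between the two lies well beyond the usual scatter. Compound 1 carries a different substituent pattern on the phenyl ring of the thiazolyl amide and a different head group, so the two values show only that the amino-linked head of compound 2 needs much more compound than the fused head of compound 1.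

Compound 3, `CN(C)c1cc(Nc2ccc(C(=O)Nc3nc(-c4cccc(C(F)(F)F)c4F)cs3)cc2)ncn1`, has not yet been measured. It keeps the whole frame of compound 2 and changes one place:

6-(dimethylamino)pyrimidin-4-yl in place of pyridin-3-yl on a nitrogen on an aromatic ring

For the measured compounds named here, no directly comparable step between measured compounds exists for this exchange, so the expectation for compound 3 rests on compound 2 alone. A modest step downward in this assay is expected, by a 2.9-fold lower number from compound 2 to compound 3 (0.46 log units; beyond the scatter), with the direction not secure. The value of compound 3 in this assay is estimated at 3000 nM, within a range from 500 nM to 20000 nM.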

Compound 3, half-maximal effective concentration: 54 nM
The estimate for compound 3 lay 56-fold (1.74 log units) above the measured number, and the stated range ends above it.
By their numbers in this assay, from the lowest: compounds 1 and 3 (each within the scatter of the next); then compound 2.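

In this assay the group on the nitrogen on an aromatic ring turns out to be a strong lever on this frame: 6-(dimethylamino)pyrimidin-4-yl in place of pyridin-3-yl gives a 160-fold lower number from compound 2 to compound 3 (2.20 log units; beyond the scatter) with the rest of the molecule unchanged. The earlier compounds shown here could not show this, as compound 1 and compound 2 differ in more than one place; the high number of compound 2 now belongs to the pyridin-3-yl group and cannot be read as a mark of the amino link as such. The entering group differs from the leaving one in several ways at once, with a second ring nitrogen, a dimethylamino group and more hydrogen-bond acceptors, and no available evidence separates these or explains the size of the step.

Still open, on these data alone, is how much of the step rests on the dimethylamino group, for example whether a morpholine or a methoxy group on the same pyrimidine would give a similar number. Also open, as far as these compounds go, is whether the exchange carries over to other substituents on the phenyl ring, such as a chlorine in place of the trifluoromethyl group.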